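Swapping a fluorophenyl for a pyridyl on the sulfur-linked chain

A few compounds are considered here, and "the series" means these few. Any claim that something is new, unique, unknown or untested is made for them only; others in the source may bear on it.

Measured compounds, with their numbers in an assay on isolated protein for inhibition of aldehyde dehydrogenase 1A1 (Homo sapiens); on this read-out higher numbers stand for weaker inhibition and lower numbers for stronger inhibition:
- compound 1 `Cn1ncc2c(=O)n(-c3ccccc3)c(SC(C)(C)c3ccccc3)nc21` gives 1900 nM
- compound 2 `CC(Sc1nc2c(cnn2C)c(=O)n1-c1ccccc1)c1ccccn1` gives 242 nM
- compound 3 `CC(Sc1nc2c(cnn2C)c(=O)n1-c1ccccc1)c1cccc(F)c1` gives 151 nM

All three share one core and differ only in the group attached to the sulfur. Compound 3 carries the lowest number of the three in this assay, yet its gap to compound 2 is within the scatter, so the two cannot be ranked; only compound 1 is clearly apart, as a 13-fold lower number from compound 1 to compound 3 (1.10 log units; beyond the scatter) shows.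

Compound 4 `CC(Sc1nc2c(cnn2C)c(=O)n1-c1ccccc1)c1cccnc1` is not yet measured. The change from compound 3 is pyridin-3-yl in place of 3-fluorophenyl on a saturated chain carbon bound to a saturated chain carbon and a sulfur.

Within the data shown here, one measured step bears on this: a 1.6-fold lower number from compound 2 to compound 3 (0.20 log units; within the scatter), where a pyridyl was exchanged for the fluorophenyl on the same chain carbon and the number barely moved. Going the other way, back to a pyridyl, is therefore expected to change little. The step of a 1.6-fold higher number from compound 3 to compound 4 (0.20 log units; within the scatter) is the estimate, with no change beyond the scatter expected. Compound 4 is estimated at 240 nM, between 100 nM and 600 nM.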

Compound 4, half-maximal inhibitory concentration: 139 nM
Beside the measured number, compound 4's estimate is 1.7-fold (0.24 log units) above it, and the stated range covers the measured number.
By their numbers in this assay, from the lowest: compounds 4, 3 and 2 (each within the scatter of the next); then compound 1.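

In this assay, a ring of carbon only bearing fluorine and a ring holding one nitrogen cannot be told apart on this saturated chain carbon (a 1.1-fold lower number from compound 3 to compound 4 (0.04 log units; within the scatter)). Pyridin-3-yl and pyridin-2-yl cannot be told apart either (a 1.7-fold lower number from compound 2 to compound 4 (0.24 log units; within the scatter)), so compound 2, compound 3 and compound 4 cannot be ranked, while the change from 1-methyl-1-phenylethyl to 1-(pyridin-3-yl)ethyl remains a clear one (a 14-fold lower number from compound 1 to compound 4 (1.14 log units; beyond the scatter)). No independent information is available to explain these results.

The compounds shown leave open whether an aromatic ring is needed on this chain carbon at all, which an amine or a carboxylic acid in its place would test. They also leave open how a longer chain carrying the pyridin-3-yl would compare.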